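A Methylphenyl Replaces the Furan on the Amide Chain

This account rests on a few compounds, and the source may have more. Where it says the series, first, only, none or still open, it means among the compounds named here.

Compound 1 `O=C(/C=C/c1ccco1)NCCNc1ccnc2cc(Cl)ccc12` was examined in an ADME assay on Vero cells (Chlorocebus sabaeus) for cytotoxicity, read by MTT assay, with a stated time of 72 h (on this read-out lower numbers stand for higher toxicity in this test and higher numbers for lower toxicity in this test), where compound 1 gives 629000 nM, the higher of the two numbers reported. Its nearest neighbour, compound 2 `COc1ccc(/C=C/C(=O)NCCNc2ccnc3cc(Cl)ccc23)cc1OC`, gives in this assay a value of 5600 nM, a far lower number, beyond the usual scatter. Compound 3 `COc1cc(/C=C/C(=O)c2ccc(OC3CO3)cc2)cc(OC)c1OC` is reported in this assay only as "not toxic" (no number reported), without a number. Compound 4 `Cc1ccc(/C=C/C(=O)NCCNc2ccnc3cc(Cl)ccc23)cc1` has not yet been measured in this assay. It differs from compound 1 in one place: 4-methylphenyl in place of furan-2-yl on a double-bonded chain carbon bound to a double-bonded chain carbon. Because compound 2 gives 5600 nM, the step is expected to run downward beyond the scatter, a 6.3-fold lower number from compound 1 to compound 4 (0.80 log units; beyond the scatter). For compound 4 the estimate in this assay is 100000 nM, expected to fall within 15000 nM to 600000 nM.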

Compound 4, half-maximal cytotoxic concentration: 4000 nM
Beside the measured number, compound 4's estimate is 25-fold (1.40 log units) above it; the whole stated range lies above it.
By their numbers in this assay, from the lowest: compounds 4 and 2 (each within the scatter of the next); then compound 1.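

In this assay, among these compounds, placing 4-methylphenyl in place of furan-2-yl on a double-bonded chain carbon bound to a double-bonded chain carbon gives a 160-fold lower number from compound 1 to compound 4 (2.20 log units; beyond the scatter), the first step at this position, and it is large. The change therefore moves the number far toward higher toxicity in this test. Nothing at hand explains this step.

As far as these compounds go, it remains open whether the step follows from losing the furan-2-yl or from gaining the phenyl ring or its methyl. An unsubstituted phenyl, a thiophene or a phenyl carrying an amine at this position would bear on that question.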